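From compound 3 to compound 4: one more methoxy

The source may report more compounds than this note shows. Statements on the series, on what has been measured and on what is new or still open speak of the compounds shown alone.

- compound 1 `COc1ccc(/C=C/C(=O)c2ccc(OCC=C(C)C)cc2O)cc1`: > 100000 nM (a limit)
- compound 2 `COc1ccc(/C=C/C(=O)c2ccc(OCC=C(C)C)cc2O)c(OC)c1OC`: > 100000 nM (a limit)
- compound 3 `COc1ccc(/C=C/C(=O)c2ccc(OCC=C(C)C)cc2O)cc1OC`: > 100000 nM (a limit)

In a functional assay on COLO 205 cells (Homo sapiens) for cytotoxicity, read by MTT assay, with a stated time of 24 h (on this read-out lower numbers stand for stronger inhibition of growth and higher numbers for weaker inhibition of growth), compound 3 gives > 100000 nM, and this is a limit and not a number. The same holds across the measured set, which sits at the limit of > 100000 nM in this assay, at which 3 of the 3 values shown sit. Compound 4 `COc1cc(/C=C/C(=O)c2ccc(OCC=C(C)C)cc2O)cc(OC)c1OC` carries a single change from compound 3: methoxy in place of hydrogen on an aromatic carbon. This places methoxy in place of hydrogen on an aromatic carbon, ortho to a methoxy group.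

Going by the values given here, two measured steps bear on this change. The same exchange appears as a step that the two limits leave unreadable from compound 1 to compound 3, and the opposite exchange as a step that the two limits leave unreadable from compound 2 to compound 3. Neither supplies a size or a direction, so no clear move is expected in this assay. The expected step is a number no higher from compound 3 to compound 4 (the limit leaves the size open), and it is a cautious estimate. A report of the limit again is the likelier outcome. For compound 4 the estimated value is 100000 nM, with an expected range from 30000 nM to 200000 nM.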

Compound 4, concentration for 50% growth inhibition: 96000 nM
The estimate for compound 4 lay 1.0-fold (0.02 log units) above the measured number; the measured number falls inside the stated range.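

With this methoxy ortho to a methoxy group, compound 4 is the only compound shown in this assay to give a number and not a limit, and the other three stay at that limit: the limit of > 100000 nM in this assay, at which 3 of the 4 values shown sit.

The change brings an at least 1.0-fold lower number from compound 3 to compound 4 (0.01 log units; that floor lies within the scatter). Going by these compounds, compound 3 has only a limit, so the real size of the step stays unknown, and the result shows only that this position accepts a further methoxy without taking the number out of the measurable range.

What the compounds shown leave open is whether another group at this position, such as a hydroxy group, an amine or a longer alkoxy chain, would give a much lower number. They also leave open whether the 3-methylbut-2-enyl ether on the other ring of the shared core could be exchanged with a similar outcome.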